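The source may hold more compounds than are shown below. What is called first, only, known or untested is meant among the compounds shown, and "the series" means these compounds.

Measured compounds in an ADME assay on HeLa cells (Homo sapiens) for cytotoxicity, read by MTT assay, with a stated time of 24 h; a lower number here means a stronger inhibitor, a higher number a weaker inhibitor:
compound 1 `CN(C)C(=S)SC(=S)N1CCCC1` gives 3090000 nM.
compound 2 `CN(C)C(=S)SC(=S)N1CCCCC1` gives a limit of the assay, > 5000000 nM.
compound 3 `CN1CCN(C(=S)SC(=S)N(C)C)CC1` gives 1220000 nM.

Among these, compound 3 holds the lowest of the two numbers; the nearest number is that of compound 1, which sits higher by a margin beyond the usual scatter. The value of compound 2 is a limit of this assay and not a number (the limit of > 5000000 nM in this assay, at which 1 of the 3 values shown sits). Going by the values given here, no pair of measured compounds differs in a single place, so no measured step is available for the series.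

Compound 4 `CN(C)C(=S)SC(=S)N1CCN(c2ccccc2)CC1` has not yet been measured in this assay. It differs from compound 3 by phenyl in place of methyl on an amine nitrogen in a ring. Among the compounds with values here, no measured pair shows what such a change does. The expectation for compound 4 is a modest step toward a lower number, a 2.0-fold lower number from compound 3 to compound 4 (0.31 log units; beyond the scatter), though a step within the scatter cannot be excluded. Compound 4 is accordingly estimated at 600000 nM in this assay, with a range from 200000 nM to 2500000 nM.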

Compound 4, half-maximal inhibitory concentration: 1610000 nM
Estimate against measurement, compound 4: 2.7-fold (0.43 log units) below; the measured number falls inside the stated range.
By their numbers in this assay, from the lowest: compounds 3, 4 and 1 (each within the scatter of the next, the first and the last beyond it). At a limit, above all of these: compound 2.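

In this assay, the amine nitrogen in the ring now has its first measured step: a 1.3-fold higher number from compound 3 to compound 4 (0.12 log units; within the scatter). Going by these compounds alone, the swap from methyl to phenyl brings in a six-membered aromatic ring of carbon, yet compound 3 and compound 4 remain within the scatter of each other, so this single-place comparison shows that the position accepts the larger group without a separation in this read-out, which the earlier compounds, with no pair differing in one place, could not show. No measured property in hand bears on this step.

As far as these compounds go, whether a benzyl group, an acetyl group or a hydroxyethyl chain on the same nitrogen would separate from methyl beyond the scatter remains open. Also open is what replacing the dimethylamino group, common to all compounds shown, with a longer-chain amine would do.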